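Cytotoxicity limits across the side-chain change

The compounds below may be only part of what the source reports. "The series", "measured", "known", "first", "only" and "open" are said of these compounds alone.

In a toxicity assay on MT2 cells (Homo sapiens) for cytotoxicity, read by XTT assay, with a stated time of 4 days (a lower number here means that less compound is tolerated, a higher number that more compound is tolerated), compound 1 (`COc1cccc(CCOc2ccc(-c3c(C)nc(C)c([C@H](OC(C)(C)C)C(=O)O)c3N3CCC(C)(C)CC3)cc2)c1`) gives >= 33500 nM, which is a limit of the assay. Compound 2 (`Cc1nc(C)c([C@H](OC(C)(C)C)C(=O)O)c(N2CCC(C)(C)CC2)c1-c1ccc(OCCc2cc(F)c(F)cc2F)cc1`) gives >= 33500 nM, also a limit, so it has no numerical position in the series. The record so far is the limit of >= 33500 nM in this assay, at which 2 of the 2 values shown sit.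

Compound 3 (`Cc1nc(C)c([C@H](OC(C)(C)C)C(=O)O)c(N2CCC(C)(C)CC2)c1-c1ccc(CCCc2ccc(F)cc2)cc1`) carries 3-(4-fluorophenyl)propyl in place of 2-(2,4,5-trifluorophenyl)ethoxy on an aromatic carbon, para to a large group: 3-(4-fluorophenyl)propyl in place of 2-(2,4,5-trifluorophenyl)ethoxy on an aromatic carbon.

Among the measured compounds shown here, the only measured step is a step that the two limits leave unreadable from compound 1 to compound 2, and it concerns the terminal aromatic group, not the change to a propyl chain. It supplies no size, so no step beyond the scatter is expected in this assay, and no direction is favoured. The expected step is an at least 1.0-fold lower number from compound 2 to compound 3 (0.00 log units; that floor lies within the scatter). For compound 3 the estimated value is 33000 nM, with an expected range from 14000 nM to 60000 nM.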

Compound 3, half-maximal cytotoxic concentration: >= 32000 nM
Compound 3: a limit, no number; the forecaster's own chance of this, stated with the estimate: 70%; the middle value is on the limit's open side.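

In this assay compound 3 gives >= 32000 nM, which is a limit of the assay and not a number. Among the compounds shown here, no step among compound 1, compound 2 and compound 3 can be read. The compounds shown leave open at what concentration any of them becomes cytotoxic, and whether the side-chain changes shift it.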